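The compounds below may be only part of what the source reports. "The series", "measured", "known", "first", "only" and "open" are said of these compounds alone.

In an ADME assay on the whole organism for pharmacokinetics, with Rattus norvegicus as the target, at a dose of 5 mg/kg by the oral route (on this read-out lower numbers stand for lower exposure and higher numbers for higher exposure at the dose given), compound 1 `CC(C)(O)c1ccc(-c2cnc3c(n2)N(CCC2CCOCC2)C(=O)CN3)cn1` gives 1700 nM and compound 2 `CO[C@H]1CC[C@@H](N2CC(=O)Nc3ncc(-c4ccc(C(C)(C)O)nc4)nc32)CC1` gives 2770 nM. These two numbers lie within the usual scatter of each other, so compound 2 stands level with compound 1 and neither can be ranked over the other. Compound 3 `CO[C@H]1CC[C@H](CN2CC(=O)Nc3ncc(-c4ccc(C(C)(C)O)nc4)nc32)CC1` has not yet been measured. It keeps the shared core of compound 2 and differs from it in one place, on a nitrogen on an aromatic ring in a ring: (4-methoxycyclohexyl)methyl in place of 4-methoxycyclohexyl on a nitrogen on an aromatic ring in a ring. Among the compounds with values here, no measured step for a change of this kind is available, so the expectation rests on little. Within the data shown here, the only guide is that compound 1 carries a different group on that nitrogen and still gives 1700 nM, while compound 2 gives 2770 nM. On that basis, no step beyond the scatter is expected in this assay, and any shift is expected to be slightly downward. The expected step is a 1.5-fold lower number from compound 2 to compound 3 (0.19 log units; within the scatter), which stays within the scatter. For compound 3 the estimated value is 1800 nM, with an expected range from 600 nM to 4500 nM.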

Compound 3, maximal plasma concentration: 700 nM
Estimate against measurement, compound 3: 2.6-fold (0.41 log units) above, within the range that was stated.
By their numbers in this assay, from the lowest: compound 3; then compounds 1 and 2 (each within the scatter of the next).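

In this assay, within the data shown here, the change to (4-methoxycyclohexyl)methyl in place of 4-methoxycyclohexyl on the nitrogen comes with a 4.0-fold lower number from compound 2 to compound 3 (0.60 log units; beyond the scatter) and is the first step at this position that lies beyond the scatter. The position therefore responds in this read-out, which the level values of the two earlier compounds could not show. The change itself is small, since both groups hold one six-membered non-aromatic ring of carbon only and one hydrogen-bond acceptor, carry no net charge and differ by a single carbon, and nothing measured here accounts for the step, which rests on this one pair of compounds.

Going by these compounds, what stays open is whether the lower number follows the length of the link between the nitrogen and the ring, as a longer chain such as a two-carbon link to the same methoxycyclohexyl ring would test. On these data alone, it is also open whether the methoxy group plays any part in the step, which an amine or a carboxylic acid in its place on the ring would address.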